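Moving methoxy from 4-methoxyphenyl to 3-methoxyphenyl

The source may report more compounds than this note shows. Statements on the series, on what has been measured and on what is new or still open speak of the compounds shown alone.

Compound 1 `COc1ccc2c(c1)c(C1CC(c3ccc(Br)cc3)=NN1C(=O)c1ccc(OC)nc1)cn2C` gives 6960 nM
Compound 2 `COc1ccc(C2=NN(C(=O)c3ccc(OC)nc3)C(c3cn(C)c4ccc(OC)cc34)C2)cc1` gives 560 nM

Both values come from a functional assay on MCF7 cells (Homo sapiens) for inhibition, read by MTT assay, with a stated time of 48 h (a lower number here means a stronger inhibitor of growth, a higher number a weaker inhibitor of growth), and compound 2 holds the lower of the two numbers. Compound 3 `COc1cccc(C2=NN(C(=O)c3ccc(OC)nc3)C(c3cn(C)c4ccc(OC)cc34)C2)c1` has the same atoms as compound 2, joined differently: 3-methoxyphenyl in place of 4-methoxyphenyl on a carbon with a double bond to nitrogen, with 3-methoxyphenyl in place of 4-methoxyphenyl on a carbon with a double bond to nitrogen.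

Among the compounds with values here, only one measured step bears on this change. It is a 12-fold lower number from compound 1 to compound 2 (1.09 log units; beyond the scatter), a large step that came with methoxy in place of bromo on an aromatic carbon. Within the data shown here, it shows that a change in the group on that carbon can move the number far, but no measured pair shifts a methoxy group in this way, so it gives only a rough scale. With compound 2 at the lower end of so small a set, a move upward is thought more likely than a move downward, and a smaller one than the measured step. The expected change is a 2.5-fold higher number from compound 2 to compound 3 (0.40 log units; beyond the scatter), and this estimate is uncertain. For compound 3 the estimated value is 1400 nM, with a range from 400 nM to 5000 nM.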

Compound 3, concentration for 50% growth inhibition: 130 nM
Compound 3: the middle estimate sits 11-fold (1.03 log units) above what was measured; the whole stated range lies above it.
By their numbers in this assay, from the lowest: compound 3; then compound 2; then compound 1.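

In this assay, the carbon with a double bond to nitrogen proves sensitive not only to which group it carries but also to how that group is built, since 3-methoxyphenyl in place of 4-methoxyphenyl gives a 4.3-fold lower number from compound 2 to compound 3 (0.63 log units; beyond the scatter) with no change in the atoms present. The earlier compounds had shown only that methoxy in place of bromo could move the number, and they gave no view of a shift of the methoxy group itself. Set against the bromo compound, 3-methoxyphenyl in place of 4-bromophenyl gives a 54-fold lower number from compound 1 to compound 3 (1.73 log units; beyond the scatter), which makes this the widest step among the three compounds and leaves compound 3 with the lowest number of the set. Nothing available here explains why the 3-methoxyphenyl group goes with the lower number.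

The compounds shown leave open whether this result belongs to the methoxy group or would also appear with another group in the same arrangement, such as 3-bromophenyl or 3-aminophenyl. They also leave open whether a longer chain, such as 3-ethoxyphenyl, would keep, lower or raise the number reached by compound 3.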